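Vinyl in Place of Chlorophenyl: What to Expect for Compound 4

The compounds below may be only part of what the source reports. "The series", "measured", "known", "first", "only" and "open" are said of these compounds alone.

Three compounds sharing one core were measured in a functional assay on MDA-MB-231 cells (Homo sapiens) for cytotoxicity, read by MTT assay, with a stated time of 48 h; on this read-out lower numbers stand for stronger inhibition and higher numbers for weaker inhibition. Compound 1 `Fc1ccc(-c2nc(-c3c[nH]c4ccccc34)co2)cc1` gives 90400 nM, compound 2 `Oc1ccc(-c2nc(-c3c[nH]c4ccccc34)co2)cc1` gives 103000 nM, and compound 3 `Clc1ccc(-c2nc(-c3c[nH]c4ccccc34)co2)cc1` gives 608000 nM, the highest number of the three and so the weakest inhibition. The steps of a 6.7-fold higher number from compound 1 to compound 3 (0.83 log units; beyond the scatter) and a 5.9-fold higher number from compound 2 to compound 3 (0.77 log units; beyond the scatter) show that exchanging fluoro or hydroxy for chloro shifts the number modestly, while a 1.1-fold higher number from compound 1 to compound 2 (0.06 log units; within the scatter) stays within the scatter. Compound 4 `C=Cc1nc(-c2c[nH]c3ccccc23)co1` makes a larger change: vinyl in place of 4-chlorophenyl on an aromatic carbon. Within the data shown here, no measured step removes the 4-chlorophenyl group altogether, so none bears directly on this change, and the expectation is uncertain; a step of a 1.6-fold higher number from compound 3 to compound 4 (0.22 log units; within the scatter) toward weaker inhibition is expected. Compound 4 is estimated at 1000000 nM, with a range from 150000 nM to 5000000 nM.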

Compound 4, half-maximal inhibitory concentration: 103000 nM
For compound 4 the middle estimate is 9.7-fold (0.99 log units) above the measured one; the measured number lies below the stated range.
By their numbers in this assay, from the lowest: compounds 1, 2 and 4 (each within the scatter of the next); then compound 3.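

In this assay the six-membered aromatic ring can leave this position without any rise in the number, since vinyl gives a 5.9-fold lower number from compound 3 to compound 4 (0.77 log units; beyond the scatter) and stands level with the hydroxy and fluoro compounds, with no change at the digits printed from compound 2 to compound 4 (within the scatter) and a 1.1-fold higher number from compound 1 to compound 4 (0.06 log units; within the scatter) as the steps from those two. Among these four compounds, then, it is the 4-chlorophenyl group that stands apart at this position, while a much smaller group does as well as 4-fluorophenyl or 4-hydroxyphenyl. Nothing shown here gives a reason for these numbers. Still open, from the compounds shown here alone, is how an amine, a carboxylic acid or a longer chain at this position would compare.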